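A few compounds are considered here, and "the series" means these few. Any claim that something is new, unique, unknown or untested is made for them only; others in the source may bear on it.

Measured compounds:
compound 1, `CCCCCCCCCCCCCCCCCC1OCC(COC(=O)CCCCC[n+]2ccsc2)O1`, 0.88 mg/kg;
compound 2, `CCCCCCCCCCCCCC1OCC(COC(=O)CCCCC[n+]2ccsc2)O1`, > 5 mg/kg.

In a functional assay on artery with platelet-activating factor receptor (Rattus norvegicus) as the target (a lower number here means that less compound is needed, a higher number that more compound is needed for the effect), compound 1 gives 0.88 mg/kg. For compound 2 the assay reports only a limit, > 5 mg/kg, so its position on the scale is known only as a bound. Compound 2 sits at the limit of > 5 mg/kg in this assay, at which 1 of the 2 values shown sits. Within the data shown here, the single measured step, an at least 5.6-fold higher number from compound 1 to compound 2 (0.75 log units; beyond the scatter), accompanies the loss of a butyl from the long saturated chain.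

Compound 3, `CCCCCCCCCCCCCCCCCCCC1OCC(COC(=O)CCCCC[n+]2ccsc2)O1`, differs from compound 2 by hexyl in place of hydrogen on a saturated chain carbon, ten or more bonds along the chain from a saturated ring carbon. This change runs in the opposite direction to the measured step and goes further along the chain than the butyl that was removed. Among the measured compounds shown here, the step from compound 1 to compound 2 is the only guide, and it suggests that restoring and extending the chain brings the dose back down; the step to compound 3 is therefore expected to be an at least 6.2-fold lower number from compound 2 to compound 3 (0.79 log units; beyond the scatter). Compound 3 is estimated at 0.8 mg/kg, with a likely range from 0.3 mg/kg to 3 mg/kg.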

Compound 3, dose for 50% inhibition: 5.1 mg/kg
Estimate against measurement, compound 3: 6.4-fold (0.80 log units) below; the whole stated range lies below it.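

In this assay lengthening the chain beyond that of compound 1 does not carry the dose further down: ethyl in place of hydrogen on this far chain carbon gives a 5.8-fold higher number from compound 1 to compound 3 (0.76 log units; beyond the scatter) and so a loss rather than a gain. Compound 1 thus needs less compound than both its shorter and its longer neighbour, and the response to chain length turns at compound 1 instead of running in one direction. Compound 2 carries only a limit, > 5 mg/kg, and the step from it to compound 3 cannot be read: the limit of > 5 mg/kg in this assay, at which 1 of the 3 values shown sits.

As far as these compounds go, what a chain of a length between those of compound 1 and compound 3 would give remains open, and so does how sharp the turn is. Also open, from the compounds shown here alone, is whether a phenyl at the end of the chain could stand in for the added carbons.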